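Trimming the Pyrrolidine Down to a Bare Amino Group

A few compounds are considered here, and "the series" means these few. Any claim that something is new, unique, unknown or untested is made for them only; others in the source may bear on it.

Going by the values given here, compound 2 `O=C(CCc1ccc(C(F)(F)F)cc1)Nc1ccc2nc(N3CCC(c4ccccc4)C3)ccc2c1` is the weaker of the two compounds measured so far in a functional assay on HEK293 cells for activation of melanin-concentrating hormone receptor 1 (Rattus norvegicus), read by inositol phosphate accumulation (on this read-out lower numbers stand for an effect already at smaller amounts and higher numbers for an effect only at larger amounts of compound), where compound 2 gives 1770 nM. Among the compounds with values here, its only neighbour is compound 1 `CC1CCCN1c1ccc2cc(NC(=O)CCc3ccc(C(F)(F)F)cc3)ccc2n1`, which in this assay gives 270 nM. Within the data shown here, the single step known so far, a 6.6-fold higher number from compound 1 to compound 2 (0.82 log units; beyond the scatter), shows that swapping one substituent for another at this spot on the shared core moves the number noticeably.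

Compound 3 `Nc1ccc2cc(NC(=O)CCc3ccc(C(F)(F)F)cc3)ccc2n1` pushes further in the direction of simplification: amino in place of 3-phenylpyrrolidin-1-yl on an aromatic carbon. The whole 3-phenylpyrrolidin-1-yl group is cut away and an amino group sits in its place on the fused two-ring core. Among the measured compounds shown here, the step from compound 1 to compound 2 only tells that this spot matters; there is no measured example of removing the ring entirely, so the direction is uncertain. A further weakening appears somewhat more likely than a return towards compound 1. The step expected in this assay is a 1.4-fold higher number from compound 2 to compound 3 (0.15 log units; within the scatter). Compound 3 is therefore expected to give about 2500 nM in this assay. The expected range runs from 600 nM to 10000 nM.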

Compound 3, half-maximal effective concentration: 720 nM
Compound 3: middle estimate off by 3.5-fold (0.54 log units), on the high side, within the range that was stated.
By their numbers in this assay, from the lowest: compound 1; then compound 3; then compound 2.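

Replacing the whole 3-phenylpyrrolidin-1-yl group with amino gives a 2.5-fold lower number from compound 2 to compound 3 (0.39 log units; beyond the scatter) in this assay and shows that a ring at this position is not needed for activation to be seen; here the bare amino group even does better than the phenyl-bearing ring. Amino does not match the 2-methylpyrrolidin-1-yl group, however, as a 2.7-fold higher number from compound 1 to compound 3 (0.43 log units; beyond the scatter) in this assay makes clear. Across these three compounds the number therefore does not simply follow group size: the amino group, with its single heavy atom, falls in the middle, the 2-methylpyrrolidin-1-yl group gives the lowest number, and the 3-phenylpyrrolidin-1-yl group gives the highest. Nothing available here explains this order.

The compounds shown leave open how much of the advantage of compound 1 comes from its ring and how much from the methyl group on that ring, a question that plain pyrrolidin-1-yl would address directly. They also leave open what happens between the two extremes, where a dimethylamino group or a piperidin-1-yl ring could show whether the number changes gradually or abruptly.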